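The source may report more compounds than this note shows. Statements on the series, on what has been measured and on what is new or still open speak of the compounds shown alone.

Measured compounds:
- compound 1 `Cc1cc(C(=O)N2CCCCc3ccccc32)ccc1CNC(=O)Nc1c(F)cccc1F`: 2.1 nM in a functional assay on HEK293 cells for agonist activity at Vasopressin V2 receptor (Homo sapiens), read by a luciferase reporter and cAMP accumulation; on this read-out higher numbers stand for an effect only at larger amounts of compound and lower numbers for an effect already at smaller amounts
- compound 2 `Cc1cc(C(=O)N2CCCCc3ccccc32)ccc1CNC(=O)N1CCC[C@H]1C(=O)O`: 680 nM
- compound 3 `COC(=O)[C@@H]1CCCN1C(=O)NCc1ccc(C(=O)N2CCCCc3ccccc32)cc1C`: 100 nM

Among these three numbers compound 3 stands second highest. Its nearest neighbour is reached by a 6.8-fold lower number from compound 2 to compound 3 (0.83 log units; beyond the scatter), its furthest by a 48-fold higher number from compound 1 to compound 3 (1.68 log units; beyond the scatter). The step now followed leads to compound 4 `CCN(CC)C(=O)[C@@H]1CCCN1C(=O)NCc1ccc(C(=O)N2CCCCc3ccccc32)cc1C`, which differs from compound 3 by diethylamino in place of methoxy on a carbonyl carbon. Among the compounds with values here, no measured step makes exactly this change. The closest comparison is a 6.8-fold lower number from compound 2 to compound 3 (0.83 log units; beyond the scatter), a modest move when the carboxylic acid became its methyl ester; the large step of a 320-fold higher number from compound 1 to compound 2 (2.51 log units; beyond the scatter) shows how much the group on that carbonyl carbon can matter. For compound 4 a step of a 1.7-fold lower number from compound 3 to compound 4 (0.22 log units; within the scatter) is expected, small and within or near the scatter. Compound 4 is therefore estimated at 60 nM, between 15 nM and 250 nM.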

Compound 4, half-maximal effective concentration: 350 nM
Beside the measured number, compound 4's estimate is 5.8-fold (0.77 log units) below it; measured number outside the range, above it.
By their numbers in this assay, from the lowest: compound 1; then compound 3; then compounds 4 and 2 (each within the scatter of the next).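

Methoxy cannot be swapped for diethylamino on this carbonyl carbon without loss: a 3.5-fold higher number from compound 3 to compound 4 (0.54 log units; beyond the scatter). The diethylamide and the carboxylic acid cannot be told apart, a 1.9-fold lower number from compound 2 to compound 4 (0.29 log units; within the scatter), so among these three groups on this carbon, only methoxy gives a clearly lower number. The (2,6-difluorophenyl)amino group stays far out of reach for this amide: a 170-fold higher number from compound 1 to compound 4 (2.22 log units; beyond the scatter).

No available evidence explains these differences. As far as these compounds go, it remains open whether a smaller amide, such as dimethylamino or plain amino on this carbonyl carbon, or a longer ester such as ethoxy, would behave like methoxy or like diethylamino.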